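The compounds below may be only part of what the source reports. "The series", "measured", "known", "first", "only" and "open" are said of these compounds alone.

Measured so far in a toxicity assay on NIH3T3 cells (Mus musculus) for cytotoxicity, read by resazurin assay; a higher number here means that more compound is needed for the effect, a lower number that less compound is needed:
compound 1, `Nc1cc(-c2ccccc2)ccc1Cn1cncc1CNc1ccc(-c2cncs2)c(-c2ccccc2)c1`: > 1000 nM
compound 2, `O=C(c1ccc(NCc2cncn2Cc2ccc(-c3ccccc3)cc2)cc1-c1ccccc1)N1CCCCC1`: > 1000 nM
compound 3, `COC(=O)c1ccc(NCc2cncn2Cc2ccccc2OC)cc1-c1ccccc1`: "not determined" (no result reported)

The value for compound 1 is a limit of this assay, not a number. The value for compound 2 is likewise a limit. Compound 3 carries no result in this assay; where it stands is framed only by the limit of > 1000 nM in this assay, at which 2 of the 3 values shown sit. Compound 4, `COC(=O)c1ccc(NCc2cncn2Cc2ccc(F)cc2F)cc1-c1ccccc1`, has not yet been measured. It differs from compound 3 by 2,4-difluorophenyl in place of 2-methoxyphenyl on a saturated chain carbon bound to an aromatic nitrogen. Going by the values given here, no step between measured compounds is known, so no size of step in this assay can be read off; none beyond the scatter is expected, and the likeliest outcome is once more a limit rather than a number. Compound 4 is expected to sit near 3000 nM in this assay, estimated between 1000 nM and 10000 nM.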

Compound 4, half-maximal effective concentration: > 1000 nM
Compound 4: only a limit was reported; the forecaster's own chance of this, stated with the estimate: 80%; the middle value does not contradict the limit.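

Compound 3 carries no result and compound 4 only a limit in this assay, so no new step can be read between them. The compounds shown leave open what number lies behind any limit: the limit of > 1000 nM in this assay, at which 3 of the 4 values shown sit.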